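Acetamido for tert-butyl on an aminopyridinyl-bearing core

The compounds below may be only part of what the source reports. "The series", "measured", "known", "first", "only" and "open" are said of these compounds alone.

The measured compounds are these:
compound 1, `COc1ccccc1Cn1c(-c2cccnc2N)nc2cccnc21`, 58000 nM
compound 2, `CC(C)(C)c1ccc(-n2c(-c3cccnc3N)nc3cccnc32)cc1`, 3900 nM
compound 3, `Nc1ncccc1-c1nc2cc(-c3cccnc3)cnc2n1-c1ccc(CNC(=O)c2ccccc2)cc1`, 8 nM

All three were tested in an in vitro assay on Sf9 cells for inhibition of RAC-alpha serine/threonine-protein kinase (Homo sapiens), read by AlphaScreen, with a stated time of 20 min; on this read-out lower numbers stand for stronger inhibition and higher numbers for weaker inhibition. Compound 1 gives 58000 nM, the highest of the three numbers. Compound 2 stands second highest; its nearest neighbour is compound 1, whose number is higher and beyond the scatter, while compound 3, the furthest, lies far below with a gap well beyond the scatter. Compound 3 gives 8 nM, the strongest result here, though it carries more than one change relative to compound 2 and so no single step can be read from that pair.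

The compound not yet measured is compound 4, `CC(=O)Nc1ccc(-n2c(-c3cccnc3N)nc3cccnc32)cc1`. It differs from compound 2 by acetamido in place of tert-butyl on an aromatic carbon. Going by the values given here, no single-point step between measured compounds is known, so the expectation rests on compound 2 alone, with compound 3 showing only that a substituted aryl at this position can go with a low number. The step is expected to be modest, toward a lower number but not clearly beyond the scatter; the estimate means a 1.6-fold lower number from compound 2 to compound 4 (0.19 log units; within the scatter). Compound 4 is estimated at 2500 nM, within 600 nM to 10000 nM.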

Compound 4, half-maximal inhibitory concentration: 1300 nM
Compound 4: middle estimate off by 1.9-fold (0.28 log units), on the high side; low and high end bracket the measured number.
By their numbers in this assay, from the lowest: compound 3; then compound 4; then compound 2; then compound 1.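

Going by these compounds alone, this is the first step in this assay that can be read at a single place: acetamido in place of tert-butyl on an aromatic carbon, para to a large group, gives a 3.0-fold lower number from compound 2 to compound 4 (0.48 log units; beyond the scatter), a modest change. The exchange keeps the count at 4 heavy atoms but swaps an all-carbon group for one with nitrogen and oxygen, 1 hydrogen-bond donor and 1 hydrogen-bond acceptor, and the number does not rise, so this position tolerates that change of atoms at equal size. No measurement shown here bears on why the number moves.

The compounds shown leave open which part of the acetamido group goes with the lower number: a primary amine, a methoxy group or a carboxylic acid at the same place would bear on that, as would a longer acyl chain such as propionamido. As far as these compounds go, compound 3, at 8 nM, differs from compound 4 in more than one place, so the steps linking it cannot be read, and whether the same exchange would give a like step on the core of compound 3 stays open.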